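From 4-hydroxypiperidin-1-yl to methylamino in the series

The compounds below may be only part of what the source reports. "The series", "measured", "known", "first", "only" and "open" are said of these compounds alone.

In an in vivo ADME assay on the whole organism for metabolic stability, with Canis familiaris (Canis lupus familiaris) as the target (a higher number here means that the compound lasts longer, a lower number that the compound disappears faster), compound 1 (`Nc1noc2ccc(-n3nc(C(F)(F)F)c4c3C(=O)N(c3ccc(-c5ccccc5CN5CCCC5)cc3F)CC4)cc12`) gives 4.9 h and compound 2 (`Nc1noc2ccc(-n3nc(C(F)(F)F)c4c3C(=O)N(c3ccc(-c5ccccc5CN5CCCC5)cc3)CC4)cc12`) gives 5.3 h while compound 3 (`Nc1noc2ccc(-n3nc(C(F)(F)F)c4c3C(=O)N(c3ccc(-c5ccccc5CN5CCC(O)CC5)cc3)CC4)cc12`) gives 6.4 h and so stands within the scatter of both. Compound 4 (`CNCc1ccccc1-c1ccc(N2CCc3c(C(F)(F)F)nn(-c4ccc5onc(N)c5c4)c3C2=O)cc1`) differs from compound 3 as follows (methylamino in place of 4-hydroxypiperidin-1-yl on a saturated chain carbon bound to an aromatic carbon): methylamino in place of 4-hydroxypiperidin-1-yl on a saturated chain carbon bound to an aromatic carbon. The closest measured precedent changes the group at that same place (a 1.2-fold higher number from compound 2 to compound 3 (0.08 log units; within the scatter)), and the other measured step, hydrogen in place of fluoro on an aromatic carbon (a 1.1-fold higher number from compound 1 to compound 2 (0.03 log units; within the scatter)), bears on it less directly. Both lie within the scatter. Going by the values given here, no measured compound carries methylamino, so the range stays wide. No shift beyond the scatter is expected in this assay for this step (a 1.3-fold lower number from compound 3 to compound 4 (0.11 log units; within the scatter)). Compound 4 is estimated at 5 h with an expected range of 2.5 h to 9.5 h for now.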

Compound 4, half-life: 7.4 h
For compound 4 the middle estimate is 1.5-fold (0.17 log units) below the measured one, and the stated range covers the measured number.
By their numbers in this assay, from the lowest: compounds 1, 2, 3 and 4 (each within the scatter of the next).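

In this assay, the group on a saturated chain carbon bound to an aromatic carbon can shrink to methylamino, with no ring, and the number still stays within the scatter: replacing 4-hydroxypiperidin-1-yl gives a 1.2-fold higher number from compound 3 to compound 4 (0.06 log units; within the scatter), and replacing pyrrolidin-1-yl gives a 1.4-fold higher number from compound 2 to compound 4 (0.14 log units; within the scatter). At this place, half-life has so far shown no shift beyond the scatter across cyclic and acyclic groups. Nothing available here explains this flat result.

Still open, going by these compounds, is whether a carboxylic acid or a longer chain at this place would shift half-life beyond the scatter. Also open, on these data alone, is whether the hydrogen-to-fluoro exchange would read the same alongside methylamino.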